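Notes on compound 4: pyridin-3-yl replacing phenyl

The source may hold more compounds than are shown below. What is called first, only, known or untested is meant among the compounds shown, and "the series" means these compounds.

Measured so far in a functional assay on the whole organism (strain Wistar) for inhibition, with Rattus norvegicus as the target, read by paw edema, with a stated time of 4 h, at a dose of 10 mg/kg by the intraperitoneal route; on this read-out lower numbers stand for less inhibition and higher numbers for more inhibition at the one dose given (going by the name of the read-out):
Compound 1 `O=C(N/N=C/c1ccccc1)c1cccnc1Nc1cccc(C(F)(F)F)c1` gives 31%.
Compound 2 `O=C(N/N=C/c1ccc(O)cc1)c1cccnc1Nc1cccc(C(F)(F)F)c1` gives 61.6%.
Compound 3 `O=C(N/N=C/c1ccc(O)c(O)c1)c1cccnc1Nc1cccc(C(F)(F)F)c1` gives 21.1%.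

Compound 1 stands second highest of the three numbers. Its nearest neighbour is compound 3, a number 9.9 percentage points lower from compound 1 to compound 3 (within the scatter), a gap within the scatter; its furthest is compound 2, a number 30.6 percentage points higher from compound 1 to compound 2 (beyond the scatter), a gap beyond the scatter. The third step, a number 40.5 percentage points lower from compound 2 to compound 3 (beyond the scatter), is also beyond the scatter.

Compound 4 `O=C(N/N=C/c1cccnc1)c1cccnc1Nc1cccc(C(F)(F)F)c1` is not yet measured. It differs from compound 1 in one place: pyridin-3-yl in place of phenyl on a carbon with a double bond to nitrogen. None of the three measured steps touches a ring nitrogen; two of them add or remove a hydroxy on an aromatic carbon, and the third puts 3,4-dihydroxyphenyl in place of phenyl on the same carbon with a double bond to nitrogen that is changed here. Among the measured compounds shown here, the only step that swaps the whole ring, a number 9.9 percentage points lower from compound 1 to compound 3 (within the scatter), stayed within the scatter, and that is the closest guide available. No step beyond the scatter is therefore expected in this assay in either direction.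

The estimate for compound 4 is 34%, within 15% to 58%, which is expected to mean a number 3 percentage points higher from compound 1 to compound 4 (within the scatter).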

Compound 4, a percentage reported as inhibition, in the whole organism at one dose (the size of the read-out at that dose, not a potency): 36%
Estimate against measurement, compound 4: 2 percentage points below, within the range that was stated.
By their numbers in this assay, from the lowest: compounds 3, 1 and 4 (each within the scatter of the next, the first and the last beyond it); then compound 2.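

In this assay, the ring nitrogen of pyridin-3-yl on this carbon with a double bond to nitrogen gives a number 5 percentage points higher from compound 1 to compound 4 (within the scatter) and so cannot be told apart from phenyl, even though the entering ring brings a hydrogen-bond acceptor that phenyl lacks. The same swap measured against the two hydroxylated rings falls on opposite sides, with a number 14.9 percentage points higher from compound 3 to compound 4 (beyond the scatter) and a number 25.6 percentage points lower from compound 2 to compound 4 (beyond the scatter) as the two steps, so compound 4 sits apart from both compound 3 and compound 2 while carrying no hydrogen-bond donor on this ring. Nothing measured in this set bears on why these steps have the sizes they have.

The compounds shown leave open whether pyridin-2-yl or pyridin-4-yl at this carbon would read like pyridin-3-yl, and whether 4-methoxyphenyl or 4-aminophenyl would read like the 4-hydroxyphenyl of compound 2. Also open, on these data alone, is whether a hydroxy on the pyridin-3-yl ring would repeat a number 30.6 percentage points higher from compound 1 to compound 2 (beyond the scatter) or leave the number where compound 4 stands.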